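The source may hold more compounds than are shown below. What is called first, only, known or untested is meant among the compounds shown, and "the series" means these compounds.

Compound 1 `O=S(=O)(c1cc(Cl)cc(Cl)c1)c1cnc2cc(F)ccc2c1-c1ccccc1F` and compound 2 `O=S(=O)(c1cc(Cl)cc(Cl)c1)c1cnc2cc(F)ccc2c1-c1cccc(F)c1` share one core and differ only in the aryl group on the aromatic carbon. Going by the values given here, in an ADME assay on microsomes from liver (Homo sapiens) for metabolic stability, tested at 2.5 uM (a lower number here means slower removal, a higher number faster removal of the compound), compound 1 gives 0.93 mL/min, while compound 2 gives 0.41 mL/min, so the step of a 2.3-fold lower number from compound 1 to compound 2 (0.36 log units; beyond the scatter) is the only measured step so far. Compound 2 thus stands at the lowest of the two numbers, and its nearest neighbour is compound 1. Compound 3 `COc1ccc(-c2c(S(=O)(=O)c3cc(Cl)cc(Cl)c3)cnc3cc(F)ccc23)cc1` is the next compound to be measured; it differs from compound 2 by 4-methoxyphenyl in place of 3-fluorophenyl on an aromatic carbon. Among the compounds with values here, no measured step has a methoxy group in it, so the single step from compound 1 to compound 2 only shows how much one change of an aryl substituent can move this assay. Compound 3 is therefore expected to give about 0.75 mL/min, within a range from 0.3 mL/min to 1.8 mL/min, an expected step of a 1.8-fold higher number from compound 2 to compound 3 (0.26 log units; within the scatter).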

Compound 3, intrinsic clearance in a liver preparation (reported as CLH), per the amount of preparation that the assay uses: 1 mL/min
Beside the measured number, compound 3's estimate is 1.3-fold (0.12 log units) below it; the measured number falls inside the stated range.
By their numbers in this assay, from the lowest: compound 2; then compounds 1 and 3 (each within the scatter of the next).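

In this assay the change to 4-methoxyphenyl gives a 2.4-fold higher number from compound 2 to compound 3 (0.39 log units; beyond the scatter) and so moves the number back up, while the comparison with the 2-fluorophenyl group gives a 1.1-fold higher number from compound 1 to compound 3 (0.03 log units; within the scatter) and separates the two compounds by no more than the scatter. On this aromatic carbon, then, compound 2 with its 3-fluorophenyl group alone stands apart among the three, and two aryl groups that differ in both substituent and substituent place give indistinguishable numbers. No evidence at hand accounts for this result.

The change from 3-fluorophenyl to 4-methoxyphenyl alters the substituent and its place together, so the compounds shown cannot tell which of the two matters; 4-fluorophenyl or 3-methoxyphenyl would separate them. From the compounds shown here alone, how an amine or a carboxylic acid on this aryl group would behave also remains open.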